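The compounds below may be only part of what the source reports. "The series", "measured", "known", "first", "only" and "open" are said of these compounds alone.

Compound 1 `Cc1ncc2c(N)c(C#N)c(N)nc2n1` gives 783000 nM in a physicochemical assay for solubility, in phosphate buffer, with a stated time of 18 h (a higher number here means a more soluble compound, a lower number a less soluble compound), the highest of the two plain numbers in this assay. Compound 3 `N#Cc1c(N)nc2nc(C3CCCCC3)ncc2c1N` gives 81000 nM, reached by the step of a 9.7-fold lower number from compound 1 to compound 3 (0.99 log units; beyond the scatter). Compound 2 `CC(C)c1ncc2c(N)c(C#N)c(N)nc2n1` gives only a limit of the assay, > 1000000 nM, so no exact number is known for it (the limit of > 1000000 nM in this assay, at which 1 of the 3 values shown sits). The step of an at least 1.2-fold higher number from compound 1 to compound 2 (0.10 log units; that floor lies within the scatter) therefore cannot be sized.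

Compound 4 `CC(C)Cc1ncc2c(N)c(C#N)c(N)nc2n1` differs from compound 1 by isopropyl in place of hydrogen on a saturated chain carbon bound to an aromatic carbon, a change that, cut one bond further out, reads methyl to isobutyl. The isobutyl chain is larger than isopropyl yet has no ring, unlike cyclohexyl, so a drop smaller than that to compound 3 is expected. The expected step is a 2.0-fold lower number from compound 1 to compound 4 (0.29 log units; within the scatter). Compound 4 is therefore estimated at 400000 nM, within 150000 nM to 1000000 nM.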

Compound 4, solubility: 268000 nM
Compound 4: the middle estimate sits 1.5-fold (0.17 log units) above what was measured, and the stated range covers the measured number.
By their numbers in this assay, from the lowest: compound 3; then compound 4; then compound 1. At a limit, above all of these: compound 2.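

In this assay, a chain with no ring is enough for a clear drop at this position, with a 2.9-fold lower number from compound 1 to compound 4 (0.47 log units; beyond the scatter). A ring is not needed for that drop, yet cyclohexyl in compound 3 still stands lower, with a 3.3-fold higher number from compound 3 to compound 4 (0.52 log units; beyond the scatter). The value of compound 2 is a limit, so an at least 3.7-fold lower number from compound 2 to compound 4 (0.57 log units; beyond the scatter) gives only a floor, though that floor lies beyond the usual scatter.

The compounds shown leave open how an amine or a carboxylic acid at this position would read. They also leave open whether a longer unbranched chain would fall further than isobutyl.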